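A few compounds are considered here, and "the series" means these few. Any claim that something is new, unique, unknown or untested is made for them only; others in the source may bear on it.

The three measured compounds share one core and differ only in the substituent on a single aromatic carbon. Compound 1 `CCCCCc1cc(C)c(C(=O)N=C(N)N)cc1S(C)(=O)=O` gives 27 nM in a functional assay for inhibition of sodium/hydrogen exchanger (Oryctolagus cuniculus); on this read-out higher numbers stand for weaker inhibition and lower numbers for stronger inhibition. Compound 2 `Cc1cc(OC(C)(C)C)c(S(C)(=O)=O)cc1C(=O)N=C(N)N` gives 9.4 nM in this assay, and compound 3 `Cc1cc(Oc2ccccc2Cl)c(S(C)(=O)=O)cc1C(=O)N=C(N)N` gives 14 nM in this assay. On these numbers compound 3 stands second highest of the three; the gap a 1.5-fold higher number from compound 2 to compound 3 (0.17 log units; within the scatter) lies within the scatter, and the gap a 1.9-fold lower number from compound 1 to compound 3 (0.29 log units; within the scatter) also lies within the scatter.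

Compound 4 `Cc1cc(-n2cccn2)c(S(C)(=O)=O)cc1C(=O)N=C(N)N` is not yet measured and differs from compound 3 in one place: 1H-pyrazol-1-yl in place of 2-chlorophenoxy on an aromatic carbon. Among the measured compounds shown here, the steps that bear on this change are those at the same aromatic carbon: a 1.9-fold lower number from compound 1 to compound 3 (0.29 log units; within the scatter) and a 1.5-fold higher number from compound 2 to compound 3 (0.17 log units; within the scatter) both stay within the scatter, and only a 2.9-fold lower number from compound 1 to compound 2 (0.46 log units; beyond the scatter) passes beyond it, modestly. Three rather different groups at this carbon thus leave the read-out in a narrow band, so a step of a 1.4-fold higher number from compound 3 to compound 4 (0.15 log units; within the scatter) is expected, which is within the scatter. Compound 4 is therefore estimated to give about 20 nM in this assay, with a range from 6 nM to 65 nM.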

Compound 4, half-maximal inhibitory concentration: 25 nM
The estimate for compound 4 lay 1.3-fold (0.10 log units) below the measured number; the measured number falls inside the stated range.
By their numbers in this assay, from the lowest: compounds 2, 3, 4 and 1 (each within the scatter of the next, the first and the last beyond it).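

In this assay the change to 1H-pyrazol-1-yl gives a 1.8-fold higher number from compound 3 to compound 4 (0.25 log units; within the scatter), so a five-membered aromatic ring with 2 hetero atoms, carrying fewer heavy atoms than 2-chlorophenoxy and no chlorine, stays in the same band at this carbon. Set against pentyl, the same group gives a 1.1-fold lower number from compound 1 to compound 4 (0.03 log units; within the scatter), and these two groups cannot be told apart here. Set against tert-butoxy, it gives a 2.7-fold higher number from compound 2 to compound 4 (0.42 log units; beyond the scatter), a modest step, which leaves tert-butoxy as the only group here that stands clear of both pentyl and 1H-pyrazol-1-yl, while 2-chlorophenoxy stays within the scatter of all three.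

Nothing available here explains these steps. From the compounds shown here alone, whether an amine, a carboxylic acid or a longer chain on this carbon would stay in the same band remains open.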